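The source may hold more compounds than are shown below. What is called first, only, known or untested is meant among the compounds shown, and "the series" means these compounds.

In a functional assay, with a stated time of 150 min (a lower number here means a stronger inhibitor, a higher number a weaker inhibitor), the three measured compounds sit close together. Compound 1 `CSc1nc(-c2ccccc2O)c(C#N)c(=O)n1C` gives 58 ug/mL, compound 2 `Cn1c(NN)nc(-c2ccccc2O)c(C#N)c1=O` gives 46 ug/mL, and compound 3 `Cn1c(NN)nc(-c2ccccc2Cl)c(C#N)c1=O` gives 62 ug/mL. Compound 3 stands within the scatter of both of its neighbours: a 1.3-fold lower number from compound 1 to compound 2 (0.10 log units; within the scatter) and a 1.3-fold higher number from compound 2 to compound 3 (0.13 log units; within the scatter) both fall inside the usual spread of repeated measurements, so no ordering among the three can be read from these numbers.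

Compound 4 `CSc1nc(-c2ccccc2Cl)c(C#N)c(=O)n1C` is the next structure, and it differs from compound 3 in one place: methylsulfanyl in place of aminoamino on an aromatic carbon. Within the data shown here, the same exchange, run in the opposite direction on the hydroxy-bearing pair, is the one measured step that bears on it, namely a 1.3-fold lower number from compound 1 to compound 2 (0.10 log units; within the scatter), which stayed within the scatter. Reversing that exchange on the chloro-bearing core therefore gives no ground to expect a shift in this assay beyond the scatter, and if anything the number would drift slightly upward. Compound 4 is accordingly estimated at 75 ug/mL, with a plausible range from 40 ug/mL to 140 ug/mL. That estimate for compound 4 amounts to an expected step of a 1.2-fold higher number from compound 3 to compound 4 (0.08 log units; within the scatter).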

Compound 4, half-maximal inhibitory concentration: 81 ug/mL
For compound 4 the middle estimate is 1.1-fold (0.03 log units) below the measured one, within the range that was stated.
By their numbers in this assay, from the lowest: compounds 2, 1, 3 and 4 (each within the scatter of the next).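

With compound 4, the exchange of aminoamino for methylsulfanyl, on the aromatic carbon between two ring nitrogen atoms, can be read on a second core, and in this assay it gives a 1.3-fold higher number from compound 3 to compound 4 (0.12 log units; within the scatter), a step of the same size as on the hydroxy-bearing pair: the same change on two cores in this assay, a 1.3-fold lower number (0.10 log units; within the scatter) from compound 1 to compound 2 and a 1.3-fold lower number (0.12 log units; within the scatter) from compound 4 to compound 3, 1.0-fold (0.02 log units) apart, within the scatter of two such steps. The exchange of hydroxy for chloro also gains a second reading, a 1.4-fold higher number from compound 1 to compound 4 (0.15 log units; within the scatter), now on the methylsulfanyl compounds, and it agrees with the step on the aminoamino compounds: the same change on two cores in this assay, a 1.3-fold higher number (0.13 log units; within the scatter) from compound 2 to compound 3 and a 1.4-fold higher number (0.15 log units; within the scatter) from compound 1 to compound 4, 1.0-fold (0.02 log units) apart, within the scatter of two such steps. The four compounds thus close a square in which neither exchange moves the number beyond the scatter on either core, and aminoamino and methylsulfanyl, which differ in their hydrogen-bond donors, are not told apart at this position in this assay.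

The compounds shown leave open whether any other group at this position, such as a simple amine, a longer chain or a carboxylic acid, would shift the number beyond the scatter. They also leave open whether the two exchanges would stay as small with a methoxy group in place of the chloro or hydroxy group.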